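The source may hold more compounds than are shown below. What is called first, only, known or untested is meant among the compounds shown, and "the series" means these compounds.

Three compounds have been measured in an assay on Sf21 cells for inhibition of high affinity nerve growth factor receptor (Homo sapiens), read by HTRF, with a stated time of 30 min, in the presence of a further agent that is not named here; a higher number here means a weaker inhibitor, a lower number a stronger inhibitor:

Compound 1 `CC1(C)c2[nH]nc(NC(=O)c3ccccc3)c2CN1Cc1ccccc1`: 1240 nM
Compound 2 `Cc1cccc(CN2Cc3c(NC(=O)c4ccccc4)n[nH]c3C2(C)C)c1`: 1100 nM
Compound 3 `CC1(C)c2[nH]nc(NC(=O)c3ccccc3)c2CN1Cc1cccc(I)c1`: 1360 nM

Compound 3 gives the number furthest from the other two, yet it is not separated from either of them by more than the scatter: the steps of a 1.1-fold higher number from compound 1 to compound 3 (0.04 log units; within the scatter) and a 1.2-fold higher number from compound 2 to compound 3 (0.09 log units; within the scatter) both fall within it. The three compounds share one core and differ only in the group on the benzyl ring.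

Compound 4 `CC1(C)c2[nH]nc(NC(=O)c3ccccc3)c2CN1Cc1cccc(Br)c1` continues this series with bromo in place of iodo on an aromatic carbon. Going by the values given here, two measured steps bear on this position: the replacement of hydrogen by iodo, a 1.1-fold higher number from compound 1 to compound 3 (0.04 log units; within the scatter), and the replacement of methyl by iodo, a 1.2-fold higher number from compound 2 to compound 3 (0.09 log units; within the scatter). Neither moved the number beyond the scatter, so a hydrogen, a methyl and an iodo at this place have given much the same result. Among the compounds with values here, no bromo analogue has been measured, so the step to compound 4 rests on the likeness of bromo to iodo and on those two steps alone. Compound 4 is therefore expected to show no step beyond the scatter, a 1.0-fold lower number from compound 3 to compound 4 (0.02 log units; within the scatter). The estimate for compound 4 in this assay is 1300 nM, with a range from 700 nM to 2500 nM.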

Compound 4, half-maximal inhibitory concentration: 940 nM
Estimate against measurement, compound 4: 1.4-fold (0.14 log units) above, and the stated range covers the measured number.
By their numbers in this assay, from the lowest: compounds 4, 2, 1 and 3 (each within the scatter of the next).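

Compound 4 adds bromo to the groups tried at this place on the benzyl ring, and in this assay all three of its new steps stay within the scatter: the exchange of one halogen for another (a 1.4-fold lower number from compound 3 to compound 4 (0.16 log units; within the scatter)), bromo in place of methyl (a 1.2-fold lower number from compound 2 to compound 4 (0.07 log units; within the scatter)) and bromo in place of hydrogen (a 1.3-fold lower number from compound 1 to compound 4 (0.12 log units; within the scatter)). Going by these compounds alone, the earlier compounds offered only one halogen, so this is the first direct reading of a change from one halogen to another here, and it leaves the number unmoved beyond the scatter. Across these four compounds, hydrogen, methyl, iodo and bromo at this place cannot be told apart, and no measured evidence is available to explain that.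

The compounds shown leave open whether an amine, a carboxylic acid, a methoxy group or a longer chain at this place would produce a step beyond the scatter. They also leave open whether any of these groups would behave differently on another carbon of the ring, and whether changing the benzoyl group on the shared core would shift the number.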